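A swap of fluoro for chloro at the assay's limit

The compounds below may be only part of what the source reports. "The series", "measured", "known", "first", "only" and "open" are said of these compounds alone.

Of the compounds shown here, three sharing the core of compound 1 have been measured in a functional assay on PANC-1 cells (Homo sapiens) for cytotoxicity, read by WST assay, with a stated time of 24 h; a higher number here means a weaker inhibitor, a lower number a stronger inhibitor. Compound 1, `O=C(CCCCCCCCCc1ccccc1)N1CCCCC1`, gives > 100000 nM, which is a limit and not a number. Compound 2, `O=C(CCCCCCCCc1ccc(O)cc1)N1CCCCC1`, gives > 100000 nM, again a limit. For the measured compounds named here, compound 3, `O=C(CCCCCCCCc1ccccc1F)N1CCCCC1`, gives 98900 nM, the only true number of the three.

The next compound, compound 4, `O=C(CCCCCCCCc1ccccc1Cl)N1CCCCC1`, changes compound 3 in one place, with chloro in place of fluoro on an aromatic carbon, ortho to a large group: chloro in place of fluoro on an aromatic carbon.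

Two measured steps lead to compound 3: a number no higher from compound 1 to compound 3 (the limit leaves the size open) and a number no higher from compound 2 to compound 3 (the limit leaves the size open). Going by the values given here, neither has a readable size, and no measured step compares one halogen with another. The expectation therefore rests mainly on compound 3 at 98900 nM. Among the compounds with values here, with no measured step to suggest a shift, no change beyond the scatter is expected in this assay, and neither direction is favoured. The expected step is a 1.2-fold lower number from compound 3 to compound 4 (0.09 log units; within the scatter). A result reported only as a limit remains possible for compound 4. The estimate for compound 4 is 80000 nM, with an expected range from 40000 nM to 140000 nM.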

Compound 4, half-maximal inhibitory concentration: > 100000 nM
Compound 4: only a limit was reported (the forecaster's own chance of this, stated with the estimate: 35%); at least 1.2-fold (0.09 log units) between middle value and limit.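

In this assay, for the compounds shown here, the change from fluoro to chloro on this aromatic carbon, ortho to a large group, is the first comparison of two halogens, and it reads as a number no lower from compound 3 to compound 4 (the limit leaves the size open). Compound 4 gives > 100000 nM, which is a limit and not a number. So this swap shows no sign of a stronger inhibitor at this position, but it does not show whether the 2-chlorophenyl compound truly differs from the 2-fluorophenyl one, and the steps from compound 1 and compound 2 to compound 4 cannot be read at all, since both ends of each are limits: the limit of > 100000 nM in this assay, at which 3 of the 4 values shown sit.

As far as these compounds go, what a methoxy group, an amine or a carboxylic acid would do on this aromatic carbon remains open, as does whether any group here can bring the value clearly away from the limit. Also open, from the compounds shown here alone, is whether a longer chain or a shorter chain would give a number that can be read with either halogen in place.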